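Swapping a trifluoromethoxy for chloro on compound 1

This account rests on a few compounds, and the source may have more. Where it says the series, first, only, none or still open, it means among the compounds named here.

Of the compounds shown here, three sharing one core have been tested in a functional assay on HepG2 cells (Homo sapiens) for antiproliferative activity, read by CCK-8 assay, with a stated time of 72 h, tested at 8 uM; on this read-out lower numbers stand for a weaker effect and higher numbers for a stronger effect at the one concentration tested. Compound 1, `Nc1ccccc1NC(=O)c1ccc(Cn2cnc3c(Nc4cccc(OC(F)(F)F)c4)nc(Cl)nc32)cc1`, gives 31.2% and stands lowest of the three. Compound 3, `Nc1ccccc1NC(=O)/C=C/c1ccc(Cn2cnc3c(Nc4cccc(OC(F)(F)F)c4)nc(Cl)nc32)cc1`, gives 37.6%, and compound 2, `Cc1ccc(Nc2nc(Cl)nc3c2ncn3Cc2ccc(/C=C/C(=O)Nc3ccccc3N)cc2)cc1`, gives 43%. The step of a number 6.4 percentage points higher from compound 1 to compound 3 (within the scatter) lengthens the amide-bearing arm, and the step of a number 5.4 percentage points lower from compound 2 to compound 3 (within the scatter) swaps the group on the nitrogen-linked ring; both stay within the scatter, while the gap from compound 1 to compound 2 lies beyond it.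

Compound 4, `Nc1ccccc1NC(=O)c1ccc(Cn2cnc3c(Nc4cccc(Cl)c4)nc(Cl)nc32)cc1`, differs from compound 1 only on the six-membered aromatic ring of carbon only: chloro in place of trifluoromethoxy on an aromatic carbon. Within the data shown here, no measured pair tests chloro at this position. The nearest guide is the change of the ring substituent from compound 2 to compound 3, which moved the number only within the scatter. A small step of either direction is therefore expected, a number 1.8 percentage points higher from compound 1 to compound 4 (within the scatter), and compound 4 is estimated at 33%, most likely between 20% and 47% in this assay.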

Compound 4, a percentage reported as inhibition, at one concentration (the size of the read-out at that concentration, not a potency): 66.7%
For compound 4 the middle estimate is 33.7 percentage points below the measured one; the measured number lies above the stated range.
By their numbers in this assay, from the lowest: compounds 1, 3 and 2 (each within the scatter of the next, the first and the last beyond it); then compound 4.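

In this assay, chloro in place of trifluoromethoxy gives a number 35.5 percentage points higher from compound 1 to compound 4 (beyond the scatter). Among these compounds, the earlier single changes all stayed within the scatter, so this is the first step in the set to shift the number clearly, and it shows that the substituent on this six-membered aromatic ring can matter far more than those steps suggested. Nothing available explains why this one swap, in which five heavy atoms leave and one enters, has so large an effect.

As far as these compounds go, whether the rise belongs to chloro itself or would also appear with fluoro, methoxy or an amino group on this aromatic carbon remains open. Also open, from the compounds shown here alone, is whether the same swap would bring a step of similar size on compound 3, which carries the longer ethenyl arm.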